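Swapping the Aromatic Group on a Sulfonyl Sulfur

This account rests on a few compounds, and the source may have more. Where it says the series, first, only, none or still open, it means among the compounds named here.

- Compound 1 `CC(O)(CSc1cccc(S(F)(F)(F)(F)F)c1)C(=O)Nc1cccc(S(F)(F)(F)(F)F)c1`: 29000 nM
- Compound 2 `CC(O)(CS(=O)(=O)c1ccc(S(F)(F)(F)(F)F)cc1)C(=O)Nc1ccc(S(F)(F)(F)(F)F)cc1`: 15700 nM
- Compound 3 `CC(O)(CS(=O)(=O)c1ccc(C(F)(F)F)cc1)C(=O)Nc1ccc(S(F)(F)(F)(F)F)cc1`: 27700 nM

These three values come from a functional assay on VCaP cells (Homo sapiens) for antiproliferative activity, read by propidium iodide staining, with a stated time of 96 h; a higher number here means a weaker inhibitor, a lower number a stronger inhibitor. Compound 3, at 27700 nM, lies within the usual scatter of both other compounds, so the numbers do not separate the three.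

Compound 4 `CC(O)(CS(=O)(=O)c1ccccc1OC(F)(F)F)C(=O)Nc1ccc(S(F)(F)(F)(F)F)cc1` differs from compound 3 in one place: 2-(trifluoromethoxy)phenyl in place of 4-(trifluoromethyl)phenyl on a sulfonyl sulfur. For the measured compounds named here, only one measured step offers a guide. It is a 1.8-fold higher number from compound 2 to compound 3 (0.25 log units; within the scatter), and it replaced one group on an aromatic carbon with another. That change left the value within the scatter. Going by the values given here, it is only a loose guide, since no measured compound carries 2-(trifluoromethoxy)phenyl, and the data cannot show how this new group will behave. With no measured sign of a large change, no step beyond the scatter is expected in this assay, in either direction. The expected change is small: a 1.2-fold lower number from compound 3 to compound 4 (0.06 log units; within the scatter). The estimate for compound 4 is 24000 nM, with an expected range from 11000 nM to 50000 nM.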

Compound 4, half-maximal inhibitory concentration: 19900 nM
The estimate for compound 4 lay 1.2-fold (0.08 log units) above the measured number; low and high end bracket the measured number.
By their numbers in this assay, from the lowest: compounds 2, 4, 3 and 1 (each within the scatter of the next).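

Putting 2-(trifluoromethoxy)phenyl in place of 4-(trifluoromethyl)phenyl on the sulfonyl sulfur gives a 1.4-fold lower number from compound 3 to compound 4 (0.14 log units; within the scatter) in this assay. This is a larger structural change than the earlier step: the ring substituent and its numbered place both differ, and a hydrogen-bond acceptor enters, yet the value stays within the scatter, so this aromatic group can be changed in both respects without a measurable shift in this assay. Nothing available explains this outcome.

Going by these compounds, it remains open whether the change of substituent and the change of ring place would each leave the value unmoved on their own; a 4-(trifluoromethoxy)phenyl group on the sulfonyl sulfur would bear on that. Also open, on these data alone, is how a cyclohexyl group, or a phenyl ring carrying an amine, would behave at this place.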